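Propyl to ethoxymethyl on a shared core in KB cells

The compounds below may be only part of what the source reports. "The series", "measured", "known", "first", "only" and "open" are said of these compounds alone.

Measured in a functional assay on KB cells (Homo sapiens) for inhibition; a higher number here means a weaker inhibitor, a lower number a stronger inhibitor:
compound 1 `N#Cc1c(N)n(COCc2ccccc2)c2ncnc(N)c12`: 118000 nM
compound 2 `CCCn1c(N)c(C#N)c2c(N)ncnc21`: 15000 nM

Within the data shown here, only two compounds on the shared core have a number so far. Compound 2 gives 15000 nM in this assay and holds the lower of the two values, so it is the stronger inhibitor of the pair, and the gap to compound 1 lies beyond the scatter.

The next compound is compound 3 `CCOCn1c(N)c(C#N)c2c(N)ncnc21`, which has not yet been measured. It differs from compound 2 as follows: ethoxy in place of ethyl on a saturated chain carbon bound to an aromatic nitrogen.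

Among the measured compounds shown here, no measured pair isolates this change, so the guidance is thin. Compound 1, whose chain also contains oxygen, shows 118000 nM in this assay and this value leans the expectation toward a higher number. The expected change is a 2.7-fold higher number from compound 2 to compound 3 (0.43 log units; beyond the scatter) and this estimated step is moderate, toward a weaker inhibitor and beyond the scatter. For compound 3 the estimate is 40000 nM with an expected range from 11000 nM to 140000 nM in this measurement.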

Compound 3, half-maximal inhibitory concentration: 138000 nM
Compound 3: middle estimate off by 3.5-fold (0.54 log units), on the low side; the range from low to high includes it.
By their numbers in this assay, from the lowest: compound 2; then compounds 1 and 3 (each within the scatter of the next).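

In this assay, putting ethoxy in place of ethyl on a saturated chain carbon bound to an aromatic nitrogen gives a 9.2-fold higher number from compound 2 to compound 3 (0.96 log units; beyond the scatter) on the shared core, so this single exchange, read as propyl to ethoxymethyl, is enough to shift the series toward a weaker inhibitor by a step beyond the scatter. Methyl in place of phenyl on a saturated chain carbon bound to an oxygen on a saturated carbon gives a 1.2-fold higher number from compound 1 to compound 3 (0.07 log units; within the scatter) and leaves the two compounds indistinguishable in this measurement, so the phenyl group of compound 1 makes no readable difference once the chain holds its oxygen. No independent measurement bears on either step, and the data offer no account of them.

On these data alone, what stays open is whether the step seen here belongs to the chain oxygen itself or to where it stands in the chain, which a longer all-carbon chain such as butyl, or an amine in the oxygen's place, would begin to separate. As far as these compounds go, it is also open whether any group at this place could bring the shared core below the number of compound 2, which gives 15000 nM in this assay.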